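Swapping a Methoxy for a Nitro Group

The source may report more compounds than this note shows. Statements on the series, on what has been measured and on what is new or still open speak of the compounds shown alone.

Compound 3 `COc1ccc(C2C(C#N)=C(N)N(c3ccc(S(N)(=O)=O)cc3)C3=C2CCCC3)cc1` gives 50% in a functional assay on Ehrlich cells (Mus musculus) for cytotoxicity, read by trypan blue exclusion, with a stated time of 2 h, tested at 10 ug/mL (on this read-out lower numbers stand for a weaker effect and higher numbers for a stronger effect at the one concentration tested), the highest of the three numbers measured. Compound 2 `N#CC1=C(N)N(c2ccc(S(N)(=O)=O)cc2)C2=C(CCCC2)C1c1ccc(O)cc1` gives 20% and compound 1 `N#CC1=C(N)N(c2ccc(S(N)(=O)=O)cc2)C2=C(CCCC2)C1c1ccccc1` gives 5%. The change to compound 4 `N#CC1=C(N)N(c2ccc(S(N)(=O)=O)cc2)C2=C(CCCC2)C1c1ccc([N+](=O)[O-])cc1` is nitro in place of methoxy on an aromatic carbon. Among the compounds with values here, no measured step swaps one group for another at this spot; the steps that touch it add a group to a bare ring carbon: a number 45 percentage points higher from compound 1 to compound 3 (beyond the scatter) and a number 15 percentage points higher from compound 1 to compound 2 (beyond the scatter), with a number 30 percentage points higher from compound 2 to compound 3 (beyond the scatter) separating the two groups. Each addition raised the number, but nothing measured shows how the nitro group itself behaves, so the expected step of a number 10 percentage points lower from compound 3 to compound 4 (within the scatter) is small and uncertain in direction. Compound 4 is therefore estimated at 40%, within 15% to 70%.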

Compound 4, a percentage reported as activity, at one concentration (the size of the read-out at that concentration, not a potency): 0%
Beside the measured number, compound 4's estimate is 40 percentage points above it, and the stated range ends above it.
By their numbers in this assay, from the lowest: compounds 4 and 1 (each within the scatter of the next); then compound 2; then compound 3.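

Nitro is the first group at this ring carbon that does not give a number clearly above the bare ring. In this assay, the change from methoxy gives a number 50 percentage points lower from compound 3 to compound 4 (beyond the scatter), the change from hydroxy gives a number 20 percentage points lower from compound 2 to compound 4 (beyond the scatter), and the change from hydrogen gives a number 5 percentage points lower from compound 1 to compound 4 (within the scatter), so putting a group here does not by itself raise the number, and the identity of the group matters. Nothing available explains this difference between the groups. As far as these compounds go, whether an amine, a chlorine atom or a longer ether such as ethoxy would behave like methoxy or like nitro at this spot remains open.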